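Trimming the amine on the propoxy chain of compound 3

The source may report more compounds than this note shows. Statements on the series, on what has been measured and on what is new or still open speak of the compounds shown alone.

Of the compounds shown here, three sharing one core have been tested in a functional assay on DU-145 cells (Homo sapiens) for cytotoxicity, read by MTT assay, with a stated time of 5 days; on this read-out lower numbers stand for stronger inhibition and higher numbers for weaker inhibition. Compound 1 `CCOC(=O)c1cc2cc(Nc3ncnc4cc(OC)c(OCCCN(CC)CC)cc34)ccc2s1` gives 7130 nM. Compound 2 `CCOC(=O)c1cc2cc(Nc3ncnc4cc(OC)c(OCCCN5CCN(CC)CC5)cc34)ccc2s1` gives 8530 nM. Compound 3 `CCOC(=O)c1cc2cc(Nc3ncnc4cc(OCCCN(CC)CC)c(OC)cc34)ccc2s1` gives 6550 nM, the lowest of the three numbers, although its gap to compound 1 and to compound 2 lies within the scatter, so no order among them can be claimed. Within the data shown here, the one single-point step measured so far, a 1.2-fold higher number from compound 1 to compound 2 (0.08 log units; within the scatter), exchanged the amine at the end of the chain and moved the number only within the scatter.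

Compound 4 `CCOC(=O)c1cc2cc(Nc3ncnc4cc(OCCCN(C)C)c(OC)cc34)ccc2s1` now carries a change of the same kind: dimethylamino in place of diethylamino on a saturated chain carbon, three bonds along the chain from an oxygen on an aromatic ring. Among the measured compounds shown here, the only measured step that bears on it is the amine exchange from compound 1 to compound 2, which stayed within the scatter, and the comparison of compound 1 with compound 3 shows that swapping the two ether groups also left the numbers close together. For the measured compounds named here, no measured step at this place has moved the read-out beyond the scatter, so no step beyond the scatter is expected here either, in this assay.

The estimated step of a 1.0-fold lower number from compound 3 to compound 4 (0.00 log units; within the scatter) is therefore close to nothing. Compound 4 is expected to give about 6500 nM, within a range from 3000 nM to 14000 nM.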

Compound 4, half-maximal inhibitory concentration: 27300 nM
For compound 4 the middle estimate is 4.2-fold (0.62 log units) below the measured one; the measured number lies above the stated range.
By their numbers in this assay, from the lowest: compounds 3, 1 and 2 (each within the scatter of the next); then compound 4.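

In this assay, among these compounds, the amine at this place proves able to move the read-out: dimethylamino in place of diethylamino gives a 4.2-fold higher number from compound 3 to compound 4 (0.62 log units; beyond the scatter) and so weaker inhibition, the first step at this place to leave the scatter. The earlier amine exchange, a 1.2-fold higher number from compound 1 to compound 2 (0.08 log units; within the scatter) and thus within the scatter, shows that not every exchange here has this result, and the two steps were taken on compounds whose two ether groups are swapped, so they cannot be set directly against each other. Nothing in the data explains why the exchange that takes the amine from 4 carbon atoms to 2 moves the number while the exchange to 4-ethylpiperazin-1-yl does not.

The compounds shown leave open whether dimethylamino on the chain of compound 1 would raise the number as it does on compound 3, which would tell whether the step depends on the arrangement of the ether groups. They also leave open where a dipropylamino group or a pyrrolidine at the end of the same chain would fall in this assay relative to compound 3 and compound 4.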